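This account rests on a few compounds, and the source may have more. Where it says the series, first, only, none or still open, it means among the compounds named here.

Measured in a functional assay on MIA PaCa-2 cells (Homo sapiens) for inhibition, read by MTT assay, with a stated time of 3 days; a higher number here means a weaker inhibitor, a lower number a stronger inhibitor:

- Compound 1 `CCN(CC)S(=O)(=O)c1ccc(S(=O)(=O)N2CCC[C@@H](C(=O)N[C@@H]3CCN(C(=O)OC(C)(C)C)C3)C2)cc1`: 500 nM
- Compound 2 `CCN1CC(NC(=O)[C@@H]2CCCN(S(=O)(=O)c3ccc(S(=O)(=O)N(CC)CC)cc3)C2)C1`: > 10000 nM, which is a limit of the assay and not a number
- Compound 3 `CC(C)c1noc(N2CCN(C(=O)[C@@H]3CCCN(S(=O)(=O)c4ccc(S(=O)(=O)NC5CC5)cc4)C3)CC2)n1`: 300 nM

Compound 3, at 300 nM, cannot be told apart from compound 1, at 500 nM. The gap between these two values lies within the usual scatter. Both therefore sit in the same range of the measured numbers.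

Compound 4 `CCN(CC)S(=O)(=O)c1ccc(S(=O)(=O)N2CCC[C@@H](C(=O)N3CCN(c4nc(C(C)C)no4)CC3)C2)cc1` is the next compound to consider. It differs from compound 3 at one place: diethylamino in place of cyclopropylamino on a sulfonyl sulfur. In words, this is diethylamino in place of cyclopropylamino on a sulfonyl sulfur.

For the measured compounds named here, only one measured step is available, an at least 20-fold higher number from compound 1 to compound 2 (1.30 log units; beyond the scatter). Going by the values given here, it is large, but it lies on an amide-type nitrogen and not on the sulfonyl sulfur, so no measured step covers this swap directly. The nearest guide is compound 1, which carries diethylamino on a sulfonyl sulfur and gives 500 nM. Compound 1 differs from compound 4 elsewhere, so this guide is only indirect.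

No change beyond the scatter is therefore expected in this assay, because compound 1 with this group gives 500 nM. The expected shift is a 1.3-fold higher number from compound 3 to compound 4 (0.12 log units; within the scatter). For compound 4 the estimated value is 400 nM, with an expected range of 120 nM to 1500 nM.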

Compound 4, half-maximal inhibitory concentration: 30 nM
For compound 4 the middle estimate is 13-fold (1.12 log units) above the measured one, outside the stated range (below it).
By their numbers in this assay, from the lowest: compound 4; then compounds 3 and 1 (each within the scatter of the next). At a limit, above all of these: compound 2.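

For the compounds shown here, putting diethylamino in place of cyclopropylamino on a sulfonyl sulfur gives a 10-fold lower number from compound 3 to compound 4 (1.00 log units; beyond the scatter) in this assay and so shows that this place can move the number well beyond the scatter, which the one earlier step, made on an amide-type nitrogen, could not show. The change takes away a three-membered ring and the hydrogen-bond donor of cyclopropylamino and adds one heavy atom, and this single pair cannot separate which of these differences matters. Nothing measured among the data shown bears on the reason for this step.

The compounds shown carry only these two groups on the sulfonyl sulfur, so it stays open how dimethylamino, a piperidine ring or an unsubstituted amine would read there. From the compounds shown here alone, it also stays open whether diethylamino in place of cyclopropylamino gives a step of similar size when the rest of the molecule changes, for example with the 1-(tert-butoxycarbonyl)pyrrolidin-3-yl group of compound 1 in place of the isopropyl-bearing part of compound 4.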